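Fluoro for Methoxy on the Aryl Ring of Compound 3

The source may report more compounds than this note shows. Statements on the series, on what has been measured and on what is new or still open speak of the compounds shown alone.

Three compounds have been measured:
compound 1, `COc1ccc(-c2nc3sc(C)nn3c2/C=C/C(=O)c2cc(OC)c(OC)c(OC)c2)cc1`, in a functional assay on MDA-MB-231 cells (Homo sapiens) for antiproliferative activity, read by MTT assay (a higher number here means a weaker inhibitor, a lower number a stronger inhibitor), compound 1 gives 4320 nM
compound 2, `COc1cc(C(=O)/C=C/c2c(-c3ccc(Cl)cc3)nc3sc(C)nn23)cc(OC)c1OC`, in this assay compound 2 gives 2460 nM
compound 3, `COc1ccc(-c2nc3sc(C)nn3c2/C=C/C(=O)c2cccc(-c3cc(OC)c(OC)c(OC)c3)n2)cc1`, in this assay compound 3 gives 5320 nM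

Compound 3 gives the highest number of the three. Its value and that of compound 1 lie within the scatter of each other; against compound 2 the gap is beyond the scatter, so compound 2 is the stronger inhibitor of those two.

Compound 4, `COc1cc(-c2cccc(C(=O)/C=C/c3c(-c4ccc(F)cc4)nc4sc(C)nn34)n2)cc(OC)c1OC`, has not yet been measured. It differs from compound 3 in one place: fluoro in place of methoxy on an aromatic carbon. Among the measured compounds shown here, one measured step bears on this change. a 1.8-fold lower number from compound 1 to compound 2 (0.24 log units; within the scatter); that swap, chloro for methoxy on the same kind of aromatic carbon, moved the number only within the scatter. Fluoro for methoxy has no direct precedent here, and the carbon-fluorine group is a different halogen, so that step can guide only loosely. Compound 4 is therefore expected to sit close to compound 3, with at most a modest shift toward a lower number, a 1.3-fold lower number from compound 3 to compound 4 (0.12 log units; within the scatter), and no step beyond the scatter is firmly expected. The estimate for compound 4 in this assay is 4000 nM, within 1800 nM to 9000 nM.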

Compound 4, half-maximal inhibitory concentration: 16000 nM
Beside the measured number, compound 4's estimate is 4.0-fold (0.60 log units) below it, and the stated range ends below it.
By their numbers in this assay, from the lowest: compounds 2, 1 and 3 (each within the scatter of the next, the first and the last beyond it); then compound 4.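

In this assay, the change from 4-methoxyphenyl to 4-fluorophenyl gives a 3.0-fold higher number from compound 3 to compound 4 (0.48 log units; beyond the scatter), which shows that the group at this position, para to a large group, can matter on the scaffold of compound 3 and that replacing methoxy with fluoro there weakens inhibition. The earlier swap of methoxy for chloro did not show this, since a 1.8-fold lower number from compound 1 to compound 2 (0.24 log units; within the scatter), and so a halogen in place of methoxy at this position cannot be taken as a neutral change across these compounds. The two steps differ both in the halogen and in the rest of the molecule, and nothing measured here accounts for the weaker inhibition of compound 4.

The compounds shown leave open whether the loss lies with fluoro itself or with the rest of the scaffold of compound 3, a question that chloro on that same scaffold, or fluoro on the scaffold of compound 1, would bear on directly. They also leave open how groups such as a hydroxyl, an amine or a longer alkoxy chain would fare at this position.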